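Moving the Methyl Group on the Aryl Ring

The compounds below may be only part of what the source reports. "The series", "measured", "known", "first", "only" and "open" are said of these compounds alone.

Compound 1 `COc1cc(-c2ccnc3cc(-c4ccc(C)cc4)nn23)cc(OC)c1OC` carries a 4-methylphenyl group on the shared core. Among the compounds with values here, in a functional assay on B16-F0 cells (Mus musculus) for inhibition, read by CCK-8 assay, with a stated time of 48 h (on this read-out lower numbers stand for stronger inhibition and higher numbers for weaker inhibition), compound 1 gives 21 nM, the lowest of the two numbers measured so far; compound 2 `COc1cc(-c2ccnc3cc(-c4cn(CO)c5ccccc45)nn23)cc(OC)c1OC` gives 93 nM, a gap beyond the usual scatter. Compound 3 `COc1cc(-c2ccnc3cc(-c4cccc(C)c4)nn23)cc(OC)c1OC` is the untested partner of compound 1: 3-methylphenyl in place of 4-methylphenyl on an aromatic carbon. Within the data shown here, no measured pair shows what this change does here, so the expected step of a 1.7-fold higher number from compound 1 to compound 3 (0.22 log units; within the scatter) is judged small, leaning only slightly toward weaker inhibition. Compound 3 is estimated at 35 nM, within 12 nM to 110 nM.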

Compound 3, half-maximal inhibitory concentration: 2220 nM
Estimate against measurement, compound 3: 63-fold (1.80 log units) below; measured number outside the range, above it.
By their numbers in this assay, from the lowest: compound 1; then compound 2; then compound 3.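

In this assay, the switch from 4-methylphenyl to 3-methylphenyl gives a 110-fold higher number from compound 1 to compound 3 (2.02 log units; beyond the scatter) on the shared core. Within the data shown here, the two compounds have the same atoms, so where the single methyl group sits on this aryl ring can by itself make a large difference. No available evidence explains why the two differ so much.

Still open, as far as these compounds go, is how an ethyl group, a methoxy group or an amine in place of the methyl group would read in this assay. The compounds shown also leave open how the unsubstituted phenyl ring compares.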